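The compounds below may be only part of what the source reports. "The series", "measured", "known", "first", "only" and "open" are said of these compounds alone.

In a physicochemical assay for solubility, at pH 7 (a higher number here means a more soluble compound, a lower number a less soluble compound), two compounds built on one shared core have been measured so far. Compound 1 (`CN1CCC(C(=O)N2Cc3c(NC(=O)NCc4ccccc4)n[nH]c3C2(C)C)CC1`) gives > 225000 nM, which is a limit of the assay and not a number. Among the measured compounds shown here, compound 2 (`CN1CCC(C(=O)N2Cc3c(NC(=O)c4ccc5ccccc5c4)n[nH]c3C2(C)C)CC1`) gives 219000 nM, the only actual number available, so it has no other number to be ranked against. Compound 3 (`CN1CCC(C(=O)N2Cc3c(NC(=O)c4ccc(Cl)cc4)n[nH]c3C2(C)C)CC1`) carries 4-chlorophenyl in place of naphthalen-2-yl on a carbonyl carbon. For the measured compounds named here, the one measured step that bears on this, an at least 1.0-fold lower number from compound 1 to compound 2 (0.01 log units; that floor lies within the scatter), changed a different pair of groups at that carbonyl carbon, and its floor lies within the scatter. Going by that step alone, no change beyond the scatter is expected in this assay. The expected step is a 1.1-fold lower number from compound 2 to compound 3 (0.04 log units; within the scatter). For compound 3 the estimated value is 200000 nM, with an expected range of 90000 nM to 250000 nM.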

Compound 3, solubility: > 225000 nM
Compound 3 ended at the assay's limit; the forecaster's own chance of this, stated with the estimate: 35%; at least 1.1-fold (0.05 log units) between middle value and limit.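

Putting 4-chlorophenyl in place of naphthalen-2-yl on the carbonyl carbon gives, in this assay, an at least 1.0-fold higher number from compound 2 to compound 3 (0.01 log units; that floor lies within the scatter). Among the compounds shown here, this means that going from two aromatic rings to one at this position produces no difference that can be told from the scatter, and this is the first comparison here between two aryl groups at that carbon. Compound 3 gives a limit of the assay and not a number, and the step between compound 1 and compound 3 cannot be read, because the readings crowd against a single ceiling: the limit of > 225000 nM in this assay, at which 2 of the 3 values shown sit.

As far as these compounds go, whether any group on this carbonyl carbon can bring the number clearly down in this assay stays open. A longer alkyl chain or a carboxylic acid there would be a different kind of test from the three groups shown.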